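The compounds below may be only part of what the source reports. "The series", "measured", "known", "first", "only" and "open" are said of these compounds alone.

Compound 1 `Cc1nn2c(C(C)c3ccc(CC(C)C)cc3)nnc2s1`: 64%
Compound 2 `CC(C)Cc1ccc(C(C)c2nnc3sc(-c4ccccc4Cl)nn23)cc1`: 64%

Both values come from a functional assay on the whole organism (strain Wistar albino) for inhibition, with Rattus norvegicus as the target, read by paw edema, with stated times of 30 min and 0.5 h, at a dose of 20 mg/kg by the oral route; on this read-out higher numbers stand for more inhibition at the one dose given (going by the name of the read-out) and lower numbers for less inhibition. Compound 2 stands level with compound 1 within the scatter, the step of no change at the digits printed from compound 1 to compound 2 (within the scatter) showing no change at the digits given. Compound 3 `CC(C)Cc1ccc(C(C)c2nnc3sc(-c4ccco4)nn23)cc1` differs from compound 2 by furan-2-yl in place of 2-chlorophenyl on an aromatic carbon. Within the data shown here, the only measured step bearing on this place on the shared core is that from compound 1 to compound 2, and it was flat, so for compound 3 a step of none beyond the scatter is expected, a number 2 percentage points lower from compound 2 to compound 3 (within the scatter). Compound 3 is therefore estimated at 62% in this assay, with a range of 48% to 75%.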

Compound 3, a percentage reported as inhibition, in the whole organism at one dose (the size of the read-out at that dose, not a potency): 36%
The estimate for compound 3 lay 26 percentage points above the measured number; measured number outside the range, below it.
By their numbers in this assay, from the lowest: compound 3; then compounds 1 and 2 (each within the scatter of the next).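

In this assay, furan-2-yl in place of 2-chlorophenyl gives a number 28 percentage points lower from compound 2 to compound 3 (beyond the scatter), and furan-2-yl in place of methyl gives a number 28 percentage points lower from compound 1 to compound 3 (beyond the scatter). This position is therefore not indifferent to its substituent: methyl and 2-chlorophenyl stand level, while furan-2-yl alone falls away. No data on hand give a reason for the drop.

Open, from the compounds shown here alone, is whether the drop follows the ring oxygen or the five-membered ring, which thiophen-2-yl or unsubstituted phenyl at this place would help separate. Also open, going by these compounds, is how an amine or a longer alkyl chain would read out here.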